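Fluoromethyl extension of the methoxyimino group in two core series

The source may report more compounds than this note shows. Statements on the series, on what has been measured and on what is new or still open speak of the compounds shown alone.

Of the compounds shown here, three have been measured in an ADME assay on liver (Homo sapiens) for metabolic stability; on this read-out higher numbers stand for a longer-lived compound and lower numbers for a shorter-lived compound. Compound 1 `CO/N=C1/C(=O)N(Cc2nc3ccccc3n2CCCCF)c2cnccc21` gives 0.433 h, and compound 3 `O=C1/C(=N/OCCF)c2ccncc2N1Cc1nc2ccccc2n1CCCCF`, which carries the change (fluoromethyl in place of hydrogen on a saturated chain carbon bound to an oxygen), gives 0.633 h. That change produced a 1.5-fold higher number from compound 1 to compound 3 (0.16 log units; within the scatter). Compound 2 `CO/N=C1/C(=O)N(Cc2nc3ccccc3n2CCCCO)c2ncccc21` belongs to a second core; how its core differs from the core of compound 1 is not broken down here. In this assay compound 2 gives 0.517 h, a number that sits within the scatter of both compound 1 and compound 3.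

Compound 4 `O=C1/C(=N/OCCF)c2cccnc2N1Cc1nc2ccccc2n1CCCCO` has not yet been measured. It differs from compound 2 by fluoromethyl in place of hydrogen on a saturated chain carbon bound to an oxygen, the same change that separates compound 1 from compound 3, made at the same place. For the measured compounds named here, the step from compound 2 to compound 4 in this assay is therefore expected to be about a 1.4-fold higher number from compound 2 to compound 4 (0.14 log units; within the scatter), resting on the single earlier step of a 1.5-fold higher number from compound 1 to compound 3 (0.16 log units; within the scatter), which itself stayed within the scatter. On that basis the estimate for compound 4 in this assay is 0.72 h, with a likely range from 0.38 h to 1.4 h.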

Compound 4, half-life: 0.733 h
Compound 4: the middle estimate sits 1.0-fold (0.01 log units) below what was measured, within the range that was stated.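

In this assay the fluoromethyl change on the core of compound 2 gave a 1.4-fold higher number from compound 2 to compound 4 (0.15 log units; within the scatter) and thus agreed with the earlier step on the core of compound 1: the same change on two cores in this assay, a 1.5-fold higher number (0.16 log units; within the scatter) from compound 1 to compound 3 and a 1.4-fold higher number (0.15 log units; within the scatter) from compound 2 to compound 4, 1.0-fold (0.01 log units) apart, within the scatter of two such steps.
Across these two cores, then, the change carried over with no visible difference, and the step seen on one core was a fair guide to the step on the other. This does not show that the change truly lengthens the half-life, as both steps lie within the scatter, and two cores are a small base from which to predict a further core.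

On these data alone, what a longer chain, an amine or a carboxylic acid in place of the fluoromethyl would give in this assay stays open. Also open, as far as these compounds go, is whether the same agreement would hold on any core beyond these two.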